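The source may hold more compounds than are shown below. What is called first, only, known or untested is meant among the compounds shown, and "the series" means these compounds.

Of the compounds shown here, two built on the same core have so far been tested in an assay on isolated protein for inhibition of Alpha-2C adrenergic receptor (Homo sapiens); on this read-out lower numbers stand for stronger inhibition and higher numbers for weaker inhibition. Compound 1 `COc1cc(CN[C@H]2C3C4CC5C6C4CC3C6C52)cc(OC)c1OC` gives 2280 nM in this assay. Compound 2 `COc1ccc(CN(C)[C@H]2C3C4CC5C6C4CC3C6C52)cc1OC` gives 993 nM in this assay, the lower of the two numbers, and the gap from compound 1 down to compound 2 is wider than the usual scatter. Compound 3 `COc1cc(CN(C)[C@H]2C3C4CC5C6C4CC3C6C52)cc(OC)c1OC` has not yet been measured in this assay. Compound 3 differs from compound 2 by methoxy in place of hydrogen on an aromatic carbon. Among the compounds with values here, no measured pair of compounds differs in just this one place, so there is nothing within these data that fixes the direction of this change. The step from compound 2 to compound 3 is expected to be a 1.5-fold higher number from compound 2 to compound 3 (0.18 log units; within the scatter) in this assay, a modest shift that might not exceed the scatter. Compound 3 is therefore expected to give about 1500 nM in this assay, within a range from 500 nM to 4500 nM.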

Compound 3, inhibition constant: 2520 nM
Compound 3: middle estimate off by 1.7-fold (0.23 log units), on the low side; low and high end bracket the measured number.
By their numbers in this assay, from the lowest: compound 2; then compounds 1 and 3 (each within the scatter of the next).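

In this assay, methoxy in place of hydrogen on this aromatic carbon, ortho to a methoxy group, brings a 2.5-fold higher number from compound 2 to compound 3 (0.40 log units; beyond the scatter), so here the added group goes with weaker inhibition, by a step beyond the usual scatter. Methyl in place of hydrogen on the amine nitrogen brings a 1.1-fold higher number from compound 1 to compound 3 (0.04 log units; within the scatter), so with this methoxy present the change at the nitrogen cannot be told apart from the scatter. Nothing measured here accounts for either step.

On these data alone, whether a smaller group on this aromatic carbon, such as fluorine or hydroxy, would also raise the number remains open. Also open, as far as these compounds go, is whether a longer chain on the amine nitrogen, such as ethyl, would behave as methyl does.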